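A few compounds are considered here, and "the series" means these few. Any claim that something is new, unique, unknown or untested is made for them only; others in the source may bear on it.

Measured compounds:

Compound 1 `COc1ccc(CNC(=O)/C(C#N)=C/c2ccc3ccccc3c2)cc1` – in a functional assay on A-431 cells (Homo sapiens) for inhibition, read by MTT assay, with a stated time of 72 h (a lower number here means a stronger inhibitor of growth, a higher number a weaker inhibitor of growth), compound 1 gives 37000 nM.
Compound 2 `COc1ccc(CNC(=O)/C(C#N)=C/c2cccc3ccccc23)cc1` – in this assay compound 2 gives 15000 nM.
Compound 3 `N#C/C(=C\c1ccc2ccccc2c1)C(=O)NCc1ccc(Cl)c(Cl)c1` – in this assay compound 3 gives 50000 nM.

Compound 4 `N#C/C(=C\c1cccc2ccccc12)C(=O)NCc1ccc(Cl)c(Cl)c1` has not yet been measured. Compounds 1 and 2 are built from the same atoms joined differently; how their two cores differ is not broken down here. Compound 2 gives the lowest number of the three, and its gaps to compound 1 and to compound 3 both lie beyond the scatter, so it is the strongest growth inhibitor so far.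

Compound 3 differs from compound 1 by 3,4-dichlorophenyl in place of 4-methoxyphenyl on a saturated chain carbon bound to an amide-type nitrogen. That change gave a 1.4-fold higher number from compound 1 to compound 3 (0.13 log units; within the scatter), a step within the scatter. Compound 4 differs from compound 2 by the same change, (3,4-dichlorophenyl in place of 4-methoxyphenyl on a saturated chain carbon bound to an amide-type nitrogen), at the same place. For the measured compounds named here, because the step of a 1.4-fold higher number from compound 1 to compound 3 (0.13 log units; within the scatter) was small, the expected step of a 1.4-fold higher number from compound 2 to compound 4 (0.15 log units; within the scatter) is likewise small, resting on the single earlier instance only. In this assay compound 4 is therefore expected to give about 21000 nM, most likely between 8000 nM and 60000 nM.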

Compound 4, concentration for 50% growth inhibition: 8000 nM
For compound 4 the middle estimate is 2.6-fold (0.42 log units) above the measured one, within the range that was stated.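

In this assay, for the compounds shown here, putting 3,4-dichlorophenyl in place of 4-methoxyphenyl on the second core gives a 1.9-fold lower number from compound 2 to compound 4 (0.27 log units; within the scatter), so on this core the swap produces no step that can be told apart from repeat scatter. Set beside the same swap on the first core, the two steps do not differ beyond what scatter allows: the same change on two cores in this assay, a 1.4-fold higher number (0.13 log units; within the scatter) from compound 1 to compound 3 and a 1.9-fold lower number (0.27 log units; within the scatter) from compound 2 to compound 4, 2.5-fold (0.40 log units) apart, within the scatter of two such steps. Going by these compounds alone, this shows that, across these two cores, the swap carried over as a small step, but with only two pairs it does not show that the swap has no effect at all, that it would stay small on a further core, or why the two steps point in opposite directions.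

The compounds shown leave open what happens when the phenyl ring carries an amine or a carboxylic acid instead of methoxy or chlorine. They also leave open whether a longer chain bearing the 3,4-dichlorophenyl group would give a different number on either core.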